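The source may hold more compounds than are shown below. What is called first, only, known or untested is meant among the compounds shown, and "the series" means these compounds.

Compound 2 `CCCS(=O)(=O)Nc1ccc(F)c(C(=O)Nc2cnc3[nH]ncc3c2)c1F` gives the higher of the two oral bioavailability numbers recorded so far: in an in vivo ADME assay on the whole organism (strain CD-1) for pharmacokinetics, with Mus musculus as the target, at a dose of 30 mg/kg by the oral route (a lower number here means that a smaller share of the oral dose reaches the circulation, a higher number that a larger share of the oral dose reaches the circulation), compound 2 reaches 100%, whereas compound 1 `CCCS(=O)(=O)Nc1ccc(Cl)c(C(=O)Nc2cnc3[nH]nc(OC)c3c2)c1F` reaches only 53% in this assay, a gap beyond the scatter. Compound 3 `CCCS(=O)(=O)Nc1ccc(Cl)c(C(=O)Nc2cnc3[nH]ncc3c2)c1F`, not yet measured, differs from compound 2 by chloro in place of fluoro on an aromatic carbon. Among the measured compounds shown here, no measured pair isolates this exchange. Compound 1, which also carries the chloro group, gives 53%, so a downward step is expected, though compound 1 differs in a second place as well. Compound 3 is estimated at 75%, range 45% to 100%, a step of a number 25 percentage points lower from compound 2 to compound 3 (beyond the scatter) expected.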

Compound 3, oral bioavailability: 67%
Compound 3: middle estimate off by 8 percentage points, on the high side; the measured number falls inside the stated range.
By their numbers in this assay, from the lowest: compound 1; then compound 3; then compound 2.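

The exchange at the aromatic carbon para to a (propylsulfonyl)amino group is now isolated: in this assay, chloro in place of fluoro gives a number 33 percentage points lower from compound 2 to compound 3 (beyond the scatter), so this position responds to the identity of the halogen. With chloro held constant, hydrogen in place of methoxy gives a number 14 percentage points higher from compound 1 to compound 3 (beyond the scatter), showing that the second place also affects oral bioavailability. Nothing available explains either step. Still open, on these data alone, is how a bromo, methyl or nitrile group at this position would compare with fluoro and chloro. Also open, as far as these compounds go, is whether the methoxy step would persist with fluoro in place of chloro.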